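The compounds below may be only part of what the source reports. "The series", "measured", "known", "first", "only" and "open" are said of these compounds alone.

Working notes on the series. Compound 1 `Nc1sc(-c2ccc(Cl)cc2)c(-c2ccc(Cl)cc2)c1C(=O)N1CCCCC1=O` gives 4940 nM in a functional assay on PC-3 cells (Homo sapiens) for inhibition, read by sulforhodamine B assay, with a stated time of 72 h; on this read-out higher numbers stand for weaker inhibition and lower numbers for stronger inhibition; compound 2 `CC1CCN(C(=O)c2c(N)sc(-c3ccc(Cl)cc3)c2-c2ccc(Cl)cc2)CC1` gives 5750 nM. For the measured compounds named here, the only measured step, a 1.2-fold higher number from compound 1 to compound 2 (0.07 log units; within the scatter), lies within the scatter, so compound 2 stands alongside compound 1, the sole other measured compound. Compound 3 `Nc1sc(-c2ccc(Cl)cc2)c(-c2ccc(Cl)cc2)c1C(=O)NC1CCCC1` carries cyclopentylamino in place of 4-methylpiperidin-1-yl on a carbonyl carbon. Going by the values given here, no measured step shows this change; the single step on the amide, a 1.2-fold higher number from compound 1 to compound 2 (0.07 log units; within the scatter), stayed within the scatter, so no step beyond the scatter is expected for compound 3 in this assay. Compound 3 is therefore expected at 5500 nM, range 2500 nM to 12000 nM, corresponding to an estimated step of a 1.0-fold lower number from compound 2 to compound 3 (0.02 log units; within the scatter).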

Compound 3, half-maximal inhibitory concentration: 21200 nM
Beside the measured number, compound 3's estimate is 3.9-fold (0.59 log units) below it; measured number above the stated range.
By their numbers in this assay, from the lowest: compounds 1 and 2 (each within the scatter of the next); then compound 3.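

In this assay the group on the carbonyl carbon can move the number: cyclopentylamino brings a 3.7-fold higher number from compound 2 to compound 3 (0.57 log units; beyond the scatter) and a 4.3-fold higher number from compound 1 to compound 3 (0.63 log units; beyond the scatter) in this series, whereas the earlier exchange of 2-oxopiperidin-1-yl for 4-methylpiperidin-1-yl stayed within the scatter. Of the compared groups, cyclopentylamino in compound 3 carries the amide hydrogen and a five-membered ring of carbon only, while 4-methylpiperidin-1-yl in compound 2 has neither.

These two features change together, so neither can be tied to the step; cyclohexylamino and pyrrolidin-1-yl on the same carbonyl carbon would separate them. No evidence on the cause of the step is available.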